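This account rests on a few compounds, and the source may have more. Where it says the series, first, only, none or still open, it means among the compounds named here.

Compound 1 `N[C@H]1CC[C@H](Nc2c(C(=O)NCc3ccc(Cl)cc3)nc(Br)c3cccnc23)CC1` — in a functional assay on MCF7 cells (Homo sapiens) for cytotoxicity, read by MTT assay, with a stated time of 72 h (on this read-out higher numbers stand for weaker inhibition and lower numbers for stronger inhibition), compound 1 gives "not determined" (no result reported).
Compound 2 `O=C(NCc1ccc(F)cc1)c1nc(Br)c2cccnc2c1N1CCNCC1` — in this assay compound 2 gives 7000 nM.

Within the data shown here, compound 1 therefore stands without a number of its own, and no single-change step connects it to compound 2. Compound 3 `N[C@H]1CC[C@H](Nc2c(C(=O)NC3CCCCC3)nc(Br)c3cccnc23)CC1` differs from compound 1 by cyclohexyl in place of 4-chlorobenzyl on an amide-type nitrogen. Among the measured compounds shown here, with no measured step between close relatives, the size and direction of the change in this assay cannot be read from the data; a shift in either direction, or none beyond the usual scatter, is possible. Compound 3 is expected to give about 6000 nM, with a range from 1000 nM to 30000 nM.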

Compound 3, half-maximal inhibitory concentration: 5200 nM
Estimate against measurement, compound 3: 1.2-fold (0.06 log units) above, within the range that was stated.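

Compound 1 has no number to set against compound 3, so no step can be read from this result. Going by these compounds, what cyclohexyl in place of 4-chlorobenzyl does in this assay stays open. No measured evidence bears on this result.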